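Swapping a four-carbon group for hydroxy at the assay limit

The source may hold more compounds than are shown below. What is called first, only, known or untested is meant among the compounds shown, and "the series" means these compounds.

Measured in an ADME assay on L1210/0 cells (Mus musculus) for cytotoxicity, with a stated time of 48 h; a higher number here means a weaker inhibitor, a lower number a stronger inhibitor:
- Compound 1 `N#Cc1cn([C@H]2C[C@H](O)[C@@H](CO)O2)c(=O)[nH]c1=O`: > 200000 nM (a limit)
- Compound 2 `C[S+]([O-])c1cn([C@H]2C[C@H](O)[C@@H](CO)O2)c(=O)[nH]c1=O`: > 200000 nM (a limit)
- Compound 3 `C=CC#Cc1cn([C@H]2C[C@H](O)[C@@H](CO)O2)c(=O)[nH]c1=O`: > 200000 nM (a limit)

None of these entries is a true number, since each one is a limit of the assay. Compound 3 stands at the limit of > 200000 nM in this assay, at which 3 of the 3 values shown sit.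

The next compound is compound 4 `O=c1[nH]c(=O)n([C@H]2C[C@H](O)[C@@H](CO)O2)cc1O`. In it, a hydroxy replaces the carbon group of compound 3 on an aromatic carbon: one oxygen atom in place of a group of 4 heavy atoms (4 carbon; no ring), on an aromatic carbon.

Within the data shown here, three measured steps bear on this change, as each exchanges one group on an aromatic carbon. They are a step that the two limits leave unreadable from compound 1 to compound 2, a step that the two limits leave unreadable from compound 1 to compound 3 and a step that the two limits leave unreadable from compound 2 to compound 3. Their sizes cannot be read, so they offer no measured trend to extend. Going by a step that the two limits leave unreadable from compound 1 to compound 3 and a step that the two limits leave unreadable from compound 2 to compound 3, no step beyond the usual scatter is expected in this assay, and no direction can be favoured. Hydroxy has not been tested among these groups, so this expectation remains uncertain, and another limit is the likeliest result. The expected change is a number no higher from compound 3 to compound 4 (the limit leaves the size open). For compound 4 the estimated value is 200000 nM, with an expected range from 60000 nM to 400000 nM.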

Compound 4, half-maximal inhibitory concentration: > 200000 nM
Compound 4 ended at the assay's limit; the forecaster's own chance of this, stated with the estimate: 65%; the middle value sits exactly at the limit.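

In this assay compound 4 gives > 200000 nM, which is a limit and not a true number. Its steps from compound 1, compound 2 and compound 3 each join two limits, so none can be read. The compounds shown leave open whether these four groups differ at all in this assay, as all stand at one place: the limit of > 200000 nM in this assay, at which 4 of the 4 values shown sit.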